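The source may report more compounds than this note shows. Statements on the series, on what has been measured and on what is new or still open speak of the compounds shown alone.

Three compounds have been measured in a functional assay on U-87MG ATCC cells (Homo sapiens) for cytotoxicity, read by MTT assay, with a stated time of 72 h; a lower number here means a stronger inhibitor, a higher number a weaker inhibitor:

- compound 1 `CN(C)CCn1cnnc1-c1cc(Oc2ccc(NC(=O)N/N=C/c3cccc(Br)c3)cc2F)ccn1` gives 830 nM
- compound 2 `CN(C)CCn1cnnc1-c1cc(Oc2ccc(NC(=O)N/N=C/c3ccc(O)c(F)c3)cc2F)ccn1` gives only a limit of the assay, > 100000 nM
- compound 3 `CN(C)CCn1cnnc1-c1cc(Oc2ccc(NC(=O)N/N=C/c3c[nH]c4ccccc34)cc2F)ccn1` gives 690 nM

Compound 1 holds the higher of the two numbers shown, but compound 3 sits within the scatter of it, so no order can be set between the two. Compound 4 `COc1ccc(/C=N/NC(=O)Nc2ccc(Oc3ccnc(-c4nncn4CCN(C)C)c3)c(F)c2)c(OC)c1OC` has not yet been measured. It differs from compound 1 at a single position: 2,3,4-trimethoxyphenyl in place of 3-bromophenyl on a carbon with a double bond to nitrogen. Two measured steps alter the very same group. The step of an at least 120-fold higher number from compound 1 to compound 2 (2.08 log units; beyond the scatter) was a large loss. Compound 2 sits at the limit of > 100000 nM in this assay, at which 1 of the 3 values shown sits. The step of a 1.2-fold lower number from compound 1 to compound 3 (0.08 log units; within the scatter), by contrast, stayed within the scatter. Among the measured compounds shown here, a new ring at this position can therefore leave the number unchanged or remove activity entirely, and none of the measured steps tells which way a 2,3,4-trimethoxyphenyl will go. The estimate for compound 4 leans toward a moderate weakening with a wide range: 2500 nM, expected between 500 nM and 30000 nM. This estimate would mean a 3.0-fold higher number from compound 1 to compound 4 (0.48 log units; beyond the scatter).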

Compound 4, half-maximal inhibitory concentration: 7650 nM
The estimate for compound 4 lay 3.1-fold (0.49 log units) below the measured number; the measured number falls inside the stated range.
By their numbers in this assay, from the lowest: compounds 3 and 1 (each within the scatter of the next); then compound 4. At a limit, above all of these: compound 2.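

In this assay, this position on a carbon with a double bond to nitrogen now shows a middle outcome, not just no clear change or a collapse to the assay limit: a 9.2-fold higher number from compound 1 to compound 4 (0.96 log units; beyond the scatter), and an 11-fold higher number from compound 3 to compound 4 (1.04 log units; beyond the scatter). The 2,3,4-trimethoxyphenyl ring therefore weakens the number but still gives a real measured value, with an at least 13-fold lower number from compound 2 to compound 4 (1.11 log units; beyond the scatter). That last step starts from a limit rather than a number for compound 2: the limit of > 100000 nM in this assay, at which 1 of the 4 values shown sits.

As far as these compounds go, what remains open is whether the weakening depends on having all the methoxy groups of compound 4 or would also appear with a simpler ring such as 4-methoxyphenyl. A ring carrying an amine, such as 4-aminophenyl, or a carboxylic acid, such as 4-carboxyphenyl, is also untested by the compounds shown here.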